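The compounds below may be only part of what the source reports. "The series", "measured", "known", "first", "only" and "open" are said of these compounds alone.

Measured so far:
compound 1 `CC(C)(C)c1ccc(CNC(=O)NCCCCl)cc1`: 17000 nM
compound 2 `CCCCCc1cccc(NC(=O)CCCCl)c1`: > 100000 nM

Two compounds have been run in a functional assay on MCF7 cells (Homo sapiens) for antiproliferative activity, with a stated time of 48 h; a lower number here means a stronger inhibitor, a higher number a weaker inhibitor. Among the measured compounds shown here, compound 1 gives 17000 nM in this assay, and this is the only real number in the set. Compound 2 gives only a limit of the assay, > 100000 nM; one of the two values shown sits at the limit of > 100000 nM in this assay, at which 1 of the 2 values shown sits. For the measured compounds named here, compound 1 therefore stands as the sole fixed point, with no measured step beside it to scale the next change.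

Compound 3 `C=CC(=O)NCc1ccc(C(C)(C)C)cc1` differs from compound 1 by vinyl in place of (3-chloropropyl)amino on a carbonyl carbon. Going by the values given here, no measured pair shows a change of this kind, so the size of the step rests on the change alone. For compound 3 a modest gain in potency is expected, the step being estimated at a 2.1-fold lower number from compound 1 to compound 3 (0.33 log units; beyond the scatter). The estimate for compound 3 in this assay is 8000 nM, with a range of 1500 nM to 40000 nM.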

Compound 3, half-maximal inhibitory concentration: > 100000 nM
Compound 3: a limit, no number (the forecaster's own chance of this, stated with the estimate: 15%); at least 12-fold (1.09 log units) between middle value and limit.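

Among the compounds shown here, on the carbonyl carbon, vinyl in place of (3-chloropropyl)amino is the first single change that can be read, and in this assay it gives an at least 5.8-fold higher number from compound 1 to compound 3 (0.76 log units; beyond the scatter). Compound 3 gives only a limit of the assay, > 100000 nM, and not a number. Compound 1 remains the only compound in the series with a number, so this position has no second measured point, and the limit now holds most of the set: the limit of > 100000 nM in this assay, at which 2 of the 3 values shown sit.

The compounds shown leave open whether the loss goes with the chlorine, the nitrogen or the chain, as the change removes all three at once. A propylamino group without the chlorine, or a hydroxypropylamino group, on the same carbonyl carbon of the shared core would begin to separate these.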